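Trifluoromethyl in place of hexyl: expected read-out

A few compounds are considered here, and "the series" means these few. Any claim that something is new, unique, unknown or untested is made for them only; others in the source may bear on it.

Compound 3 `CCCCCCc1ccc(NC(=O)N[C@H](C)c2ccccc2)cc1` stands highest of the three measured compounds, giving 101% in an ADME assay on the whole organism with Oryza sativa as the target, tested at 10 uM; on this read-out lower numbers stand for a stronger effect and higher numbers for a weaker effect at the one concentration tested. Compound 2 `C[C@@H](NC(=O)Nc1ccc(C(C)(C)C)cc1)c1ccccc1` gives 53% in this assay, and compound 1 `CCc1ccc(NC(=O)N[C@H](C)c2ccccc2)cc1` gives 44%; both sit beyond the scatter below compound 3. Compound 4 `C[C@@H](NC(=O)Nc1ccc(C(F)(F)F)cc1)c1ccccc1` differs from compound 3 in one place: trifluoromethyl in place of hexyl on an aromatic carbon. Among the measured compounds shown here, the steps that bear on this are the two that brought the hexyl in: a number 48 percentage points higher from compound 2 to compound 3 (beyond the scatter) and a number 57 percentage points higher from compound 1 to compound 3 (beyond the scatter), whereas a number 9 percentage points higher from compound 1 to compound 2 (within the scatter). Since taking the hexyl out again reverses those two large steps, compound 4 is expected to fall back toward the numbers of compound 1 and compound 2, a step of a number 53 percentage points lower from compound 3 to compound 4 (beyond the scatter). Compound 4 is therefore estimated at 48%, with a range from 30% to 70%.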

Compound 4, a percentage reported as activity, at one concentration (the size of the read-out at that concentration, not a potency): 82%
Compound 4: middle estimate off by 34 percentage points, on the low side, and the stated range ends below it.
By their numbers in this assay, from the lowest: compounds 1 and 2 (each within the scatter of the next); then compound 4; then compound 3.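

In this assay, a high number at this aromatic carbon is not tied to the hexyl chain: a number 19 percentage points lower from compound 3 to compound 4 (beyond the scatter) takes back only part of what hexyl added. Trifluoromethyl also stands apart from the two smaller alkyl groups, with a number 29 percentage points higher from compound 2 to compound 4 (beyond the scatter) and a number 38 percentage points higher from compound 1 to compound 4 (beyond the scatter) in the series. No measurement available here accounts for this separation. From the compounds shown here alone, whether a butyl chain would give a number nearer ethyl or hexyl remains open. So does where an amine or a methoxy group at this carbon would fall.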